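The source may report more compounds than this note shows. Statements on the series, on what has been measured and on what is new or still open speak of the compounds shown alone.

Compound 1 `COc1cc(OC)c(-c2nc3cc(/C=C4\SC(=O)NC4=O)ccc3[nH]2)cc1OC` — 15400 nM
Compound 2 `COc1cc(OC)c(-c2nc3cc(/C=C4\SC(=O)N(CC(=O)N5CCCCC5)C4=O)ccc3[nH]2)cc1OC` — 6890 nM

In a functional assay on HeLa cells (Homo sapiens) for inhibition, read by MTT assay, with a stated time of 48 h (on this read-out higher numbers stand for weaker inhibition and lower numbers for stronger inhibition), compound 1 gives 15400 nM. Within the data shown here, compound 2 gives 6890 nM in this assay, the lower of the two numbers, and the one step that joins them is a 2.2-fold lower number from compound 1 to compound 2 (0.35 log units; beyond the scatter). Compound 3, `COc1cc(OC)c(-c2nc3cc(/C=C4\SC(=O)N(Cc5cccc(C)c5)C4=O)ccc3[nH]2)cc1OC`, keeps a substituent on that nitrogen but changes what it carries: 3-methylphenyl in place of (piperidin-1-yl)carbonyl on a saturated chain carbon bound to an amide-type nitrogen in a ring. Among the measured compounds shown here, no measured step exchanges one such group for another; the single step known concerns attaching a group to a bare nitrogen, and it was modest. The expectation for compound 3 therefore rests on thin ground: a step of a 1.1-fold lower number from compound 2 to compound 3 (0.03 log units; within the scatter) is expected, small enough to stay within the scatter of this assay. Compound 3 is accordingly estimated at 6500 nM, with a range from 2500 nM to 16000 nM to reflect that uncertainty.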

Compound 3, half-maximal inhibitory concentration: 180 nM
Beside the measured number, compound 3's estimate is 36-fold (1.56 log units) above it, outside the stated range (below it).
By their numbers in this assay, from the lowest: compound 3; then compound 2; then compound 1.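

In this assay, the amide-type nitrogen in a ring proves far more sensitive to what it carries than the earlier step suggested: 3-methylphenyl in place of (piperidin-1-yl)carbonyl on the saturated chain carbon gives a 38-fold lower number from compound 2 to compound 3 (1.58 log units; beyond the scatter) in one exchange. Set against the bare nitrogen, 3-methylbenzyl gives an 86-fold lower number from compound 1 to compound 3 (1.93 log units; beyond the scatter), so across these three compounds the identity of the group counts for much more than the mere presence of a substituent. Nothing presented here explains why the two groups differ so widely.

On these data alone, whether a plain benzyl group, without the methyl, would match 3-methylbenzyl remains open, as does the effect of a longer chain carrying the aromatic ring. It is also unclear whether losing the carbonyl or gaining the aromatic ring drives the change, a question that a chain ending in an amine such as piperidine, with no carbonyl, could help separate.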